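The source may report more compounds than this note shows. Statements on the series, on what has been measured and on what is new or still open speak of the compounds shown alone.

Measured so far in an assay on HEK293 cells for negative allosteric modulation of metabotropic glutamate receptor 5 (Homo sapiens), read by FLIPR; on this read-out higher numbers stand for weaker inhibition and lower numbers for stronger inhibition:
compound 1 `O=C(C1CCCCC1)N1CC(c2nc(-c3cccc(F)c3)no2)C1`: > 10000 nM
compound 2 `O=C(C1CCC(C(F)(F)F)CC1)N1CC(c2nc(-c3cccc(F)c3)no2)C1`: > 10000 nM

Both readings are limits of the assay, not numbers. Compound 2 sits at the limit of > 10000 nM in this assay, at which 2 of the 2 values shown sit, so no number places it. Going by the values given here, the one measured step, a step that the two limits leave unreadable from compound 1 to compound 2, lies between two limits and cannot be read. Compound 3 `O=C(C1CCC(C(F)(F)F)CC1)N1CC(c2nc(-c3cccc(Cl)c3)no2)C1` differs from compound 2 by chloro in place of fluoro on an aromatic carbon. Among the compounds with values here, no measured step bears on this change, and the series holds no step of readable size. A reading at the limit again is therefore expected for compound 3, with the step that the limit leaves unreadable from compound 2 to compound 3. Compound 3 is estimated at 15000 nM, expected between 4000 nM and 60000 nM.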

Compound 3, half-maximal inhibitory concentration: > 10000 nM
Compound 3: only a limit was reported; the forecaster's own chance of this, stated with the estimate: 75%; the middle value is on the limit's open side.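

In this assay compound 2 and compound 3 both give only a limit, so no step can be read between them: the limit of > 10000 nM in this assay, at which 3 of the 3 values shown sit.

The compounds shown leave open what size of effect, if any, the trifluoromethyl and chloro changes have on inhibition.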